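Naphthyl sulfonamide with the octadecyl amide chain

A few compounds are considered here, and "the series" means these few. Any claim that something is new, unique, unknown or untested is made for them only; others in the source may bear on it.

Compound 2 `CCCCCCCCCCCCCCCCCCNC(=O)[C@@H](NS(=O)(=O)c1ccc(C)cc1)[C@@H](C)O` stands at the weaker end of the two numbers in hand: in a functional assay on HepG2 cells (Homo sapiens) for cytotoxicity, read by MTT assay, with a stated time of 48 h (a lower number here means a stronger inhibitor, a higher number a weaker inhibitor), compound 2 gives 75800 nM. Among the measured compounds shown here, its only measured neighbour is compound 1 `CCCCCCCCCCCCCCNC(=O)[C@@H](NS(=O)(=O)c1ccc2ccccc2c1)[C@@H](C)O`, which carries a shorter amide chain together with a naphthalene sulfonyl group; in this assay compound 1 gives 11400 nM, a lower number than that of compound 2 and beyond the scatter. For the measured compounds named here, compound 1 and compound 2 differ in two places at once, so no single-change step between measured compounds is available, and the two values show only the combined outcome.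

Compound 3 `CCCCCCCCCCCCCCCCCCNC(=O)[C@@H](NS(=O)(=O)c1ccc2ccccc2c1)[C@@H](C)O` keeps the octadecyl amide chain of compound 2 and changes the sulfonyl substituent: naphthalen-2-yl in place of 4-methylphenyl on a sulfonyl sulfur. This brings in the aryl group of compound 1 without its chain length. The expectation is a modest lowering of the number, not a return to the level of compound 1, because the value of compound 1 11400 nM cannot be assigned to the aryl change alone. The step from compound 2 to compound 3 is estimated at a 2.2-fold lower number from compound 2 to compound 3 (0.34 log units; beyond the scatter), in the direction of a lower number and near the edge of the scatter. For compound 3 the estimate in this assay is 35000 nM, with a range from 12000 nM to 100000 nM.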

Compound 3, half-maximal inhibitory concentration: 19800 nM
Compound 3: middle estimate off by 1.8-fold (0.25 log units), on the high side, and the stated range covers the measured number.
By their numbers in this assay, from the lowest: compounds 1 and 3 (each within the scatter of the next); then compound 2.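

Notes on the sulfonyl position: with the octadecyl amide chain held fixed, naphthalen-2-yl in place of 4-methylphenyl on a sulfonyl sulfur gives a 3.8-fold lower number from compound 2 to compound 3 (0.58 log units; beyond the scatter) in this assay, so the aryl change now has a size of its own, modest but beyond the scatter. With naphthalen-2-yl held fixed, butyl in place of hydrogen on a saturated chain carbon gives a 1.7-fold higher number from compound 1 to compound 3 (0.24 log units; within the scatter), which lies within the scatter, so this chain extension shows no readable effect on the number in this pair. No measurement at hand bears on the origin of either result.

On these data alone, the aryl step is known only with the octadecyl chain and the chain step only with naphthalen-2-yl, so it remains open whether either holds when the other group is changed. Also open, as far as these compounds go, is how the number responds to an amine or a carboxylic acid on the aryl group at the sulfonyl sulfur, or to a chain longer than octadecyl on the amide.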